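Extending the Anilide Ring of a Boron-Containing Antiproliferative

A few compounds are considered here, and "the series" means these few. Any claim that something is new, unique, unknown or untested is made for them only; others in the source may bear on it.

Measured so far:
compound 1, `O=C(CCc1cccc2c1B(O)OC2)Nc1ccccc1` — 200 nM
compound 2, `COc1ccc(NC(=O)CCc2cccc3c2B(O)OC3)cc1` — 900 nM

In a functional assay on SK-OV-3 cells (Homo sapiens) for antiproliferative activity, read by MTT assay, with a stated time of 72 h (on this read-out lower numbers stand for stronger inhibition and higher numbers for weaker inhibition), compound 1 gives 200 nM, the lowest of the two numbers measured; the nearest is compound 2, which in this assay gives 900 nM. Among the compounds with values here, the one step measured, a 4.5-fold higher number from compound 1 to compound 2 (0.65 log units; beyond the scatter), came from a methoxy in place of hydrogen on an aromatic carbon of the anilide ring.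

Compound 3, `COc1ccc(-c2cccc(NC(=O)CCc3cccc4c3B(O)OC4)c2)cc1`, is not yet measured. It differs from compound 1 as follows: 4-methoxyphenyl in place of hydrogen on an aromatic carbon. The entering group sits on the same ring that carried the methoxy in compound 2, though at a different carbon, meta to a large group, and it brings a whole extra aromatic ring rather than a single methoxy. Within the data shown here, the only step that bears on this is a 4.5-fold higher number from compound 1 to compound 2 (0.65 log units; beyond the scatter), which was modest and went toward weaker inhibition. The change here is larger, so a shift in this assay toward a higher number is expected, probably of similar or somewhat smaller size, without firm grounds for more.

Compound 3 is therefore expected to show a 2.5-fold higher number from compound 1 to compound 3 (0.40 log units; beyond the scatter), giving an estimated 500 nM, in a range from 150 nM to 1600 nM.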

Compound 3, half-maximal inhibitory concentration: 48 nM
Compound 3: middle estimate off by 10-fold (1.02 log units), on the high side, and the stated range ends above it.
By their numbers in this assay, from the lowest: compound 3; then compound 1; then compound 2.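

On the anilide ring of compound 1, a larger group does not have to weaken the read-out: in this assay 4-methoxyphenyl in place of hydrogen on an aromatic carbon, meta to a large group, gives a 4.2-fold lower number from compound 1 to compound 3 (0.62 log units; beyond the scatter) and so moves the opposite way from a 4.5-fold higher number from compound 1 to compound 2 (0.65 log units; beyond the scatter) on the same ring. The earlier pair alone gave no sign that this ring could accept 8 more heavy atoms, including a whole six-membered aromatic ring, and still give a lower number. Nothing available explains the difference between the two steps, which also differ in the carbon that carries the new group.

Going by these compounds, it remains open whether a plain phenyl would do as well as 4-methoxyphenyl, and whether the methoxy on the added ring contributes to the lower number at all. Also open, on these data alone, are how an amine or a carboxylic acid would read in place of that methoxy, and how 4-methoxyphenyl would read on the carbon that carries the methoxy in compound 2.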